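A few compounds are considered here, and "the series" means these few. Any claim that something is new, unique, unknown or untested is made for them only; others in the source may bear on it.

Of the compounds shown here, three have been tested in a functional assay on MCF7 cells (Homo sapiens) for cytotoxicity, read by MTT assay, with a stated time of 72 h; a lower number here means a stronger inhibitor of growth, a higher number a weaker inhibitor of growth. Compound 1, `CSc1nc(NCCCCCO)c2ccccc2n1`, gives only a limit of the assay, > 100000 nM, which is where the limit of > 100000 nM in this assay, at which 1 of the 3 values shown sits, sits. Compound 2, `CCCCCSc1nc(NCc2ccc([Se]C)cc2)c2ccccc2n1`, gives 75200 nM. Compound 3, `C[Se]c1nc([Se]C)c2ccccc2n1`, gives 50700 nM, and the two numbers lie within the usual scatter of each other, so neither can be called the stronger inhibitor of growth. Compound 2 thus holds the higher of the two numbers, with compound 3 close by.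

The step to be followed leads from compound 2 to compound 4, `CSc1nc(NCc2ccc([Se]C)cc2)c2ccccc2n1`. The change is hydrogen in place of butyl on a saturated chain carbon bound to a sulfur, with the rest of the molecule kept as it is. Within the data shown here, no measured pair shows the same change, so the expectation rests on compound 1 and compound 3 alone; neither points to a gain. Compound 4 is therefore expected to sit near compound 2 or somewhat higher, a step of a 1.3-fold higher number from compound 2 to compound 4 (0.12 log units; within the scatter) that may not exceed the scatter, with a value estimated at 100000 nM, between 40000 nM and 250000 nM.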

Compound 4, concentration for total growth inhibition: > 100000 nM
Compound 4: a limit, no number (the forecaster's own chance of this, stated with the estimate: 40%); the middle value lies on the limit itself.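

Among these compounds, compound 2 and compound 4 are the first pair that differ in one place, which gives the first direct reading of the chain on the sulfur. In this assay, the change from pentylsulfanyl to methylsulfanyl, hydrogen in place of butyl on a saturated chain carbon bound to a sulfur, gives an at least 1.3-fold higher number from compound 2 to compound 4 (0.12 log units; that floor lies within the scatter), so removing the butyl brings no lower number. The result for compound 4 is a limit and not a number: the limit of > 100000 nM in this assay, at which 2 of the 4 values shown sit.

On these data alone, how far compound 4 truly lies from compound 2 remains open, as the step gives only a floor with no upper end. Also open, as far as these compounds go, is how a longer chain such as octyl, or a chain ending in an amine or a carboxylic acid, would read on this sulfur.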